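The compounds below may be only part of what the source reports. "The series", "measured", "known", "first", "only" and "open" are said of these compounds alone.

Measured in a functional assay on HCT-116 cells (Homo sapiens) for inhibition, read by sulforhodamine B assay, with a stated time of 48 h; a higher number here means that more compound is tolerated, a lower number that less compound is tolerated:
- compound 1 `Cc1ccc(C2=NN(c3ccc(S(C)(=O)=O)cc3)C(=O)CC2)cc1`: > 100000 nM (a limit)
- compound 2 `Cc1cc(O)ccc1C1=NN(c2ccc(S(C)(=O)=O)cc2)C(=O)CC1`: > 100000 nM (a limit)

In this assay compound 2 gives > 100000 nM, which is a limit and not a number. Among the measured compounds shown here, nothing yet ranks it against compound 1, and the only evidence so far is the limit of > 100000 nM in this assay, at which 2 of the 2 values shown sit.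

Next is compound 3 `CCc1ccc(C2=NN(c3ccc(S(C)(=O)=O)cc3)C(=O)CC2)cc1`, with 4-ethylphenyl in place of 4-hydroxy-2-methylphenyl on a carbon with a double bond to nitrogen.

For the measured compounds named here, one measured step bears on this place: a step that the two limits leave unreadable from compound 1 to compound 2. It gives neither a size nor a direction. With both measured compounds resting on (the limit of > 100000 nM in this assay, at which 2 of the 2 values shown sit), no step beyond the scatter is expected in this assay, and another limit is the likely report. The estimated step is a number no higher from compound 2 to compound 3 (the limit leaves the size open). For compound 3 the expected value is 100000 nM, with an estimated range of 50000 nM to 200000 nM.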

Compound 3, concentration lethal to 50% of the cells: > 100000 nM
Compound 3: only a limit was reported; the forecaster's own chance of this, stated with the estimate: 85%; the middle value lies on the limit itself.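

In this assay, among the compounds shown here, compound 3 gives > 100000 nM, a limit and not a number, so no step from compound 1 or compound 2 to compound 3 can be read. The compounds shown leave open whether any change at this place gives a number rather than a limit: the limit of > 100000 nM in this assay, at which 3 of the 3 values shown sit.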